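Swapping the Cap: From Carbamate to Indolyl Acrylamide

A few compounds are considered here, and "the series" means these few. Any claim that something is new, unique, unknown or untested is made for them only; others in the source may bear on it.

The series builds on a hydroxamic acid chain carrying a benzylamide, with a variable group on the remaining amide carbonyl. In a functional assay on NFF cells (Homo sapiens) for antiproliferative activity (on this read-out higher numbers stand for weaker inhibition and lower numbers for stronger inhibition), compound 1 `O=C(/C=C/c1ccccc1)N[C@@H](CCCCCC(=O)NO)C(=O)NCc1ccccc1` gives 4010 nM. Among the measured compounds shown here, compound 2 `O=C(CCCCC[C@H](NC(=O)OCc1ccccc1)C(=O)NCc1ccccc1)NO`, which carries a carbamate group, gives 1520 nM in this assay and so stands lowest of the two numbers measured, with compound 1 the only neighbour. For the measured compounds named here, the single measured step, a 2.6-fold lower number from compound 1 to compound 2 (0.42 log units; beyond the scatter), shows that replacing the 2-phenylethenyl cap with benzyloxy lowered the number modestly.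

Compound 3 `O=C(/C=C/c1c[nH]c2ccccc12)N[C@@H](CCCCCC(=O)NO)C(=O)NCc1ccccc1` reverses that direction: 2-(1H-indol-3-yl)ethenyl in place of benzyloxy on a carbonyl carbon. The enamide linkage returns, now bearing an indole in place of the phenyl ring, and the carbamate oxygen is lost. Going by the values given here, the only relevant step, a 2.6-fold lower number from compound 1 to compound 2 (0.42 log units; beyond the scatter), run backwards points toward a higher number for compound 3 than for compound 2; how the indole changes matters is not known from these two compounds. A modest rise is therefore expected, with the estimated step of a 2.0-fold higher number from compound 2 to compound 3 (0.30 log units; within the scatter). Compound 3 is expected to give about 3000 nM in this assay, within a range from 1000 nM to 9000 nM.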

Compound 3, half-maximal inhibitory concentration: 10400 nM
Beside the measured number, compound 3's estimate is 3.5-fold (0.54 log units) below it; the measured number lies above the stated range.
By their numbers in this assay, from the lowest: compound 2; then compound 1; then compound 3.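

In this assay the aromatic group at the end of the enamide cap proves to matter on its own: 1H-indol-3-yl in place of phenyl on the double-bonded chain carbon gives a 2.6-fold higher number from compound 1 to compound 3 (0.41 log units; beyond the scatter), so the earlier phenyl compound did not set the ceiling for this cap type. Measured against the carbamate, the change to 2-(1H-indol-3-yl)ethenyl on the carbonyl carbon gives a 6.8-fold higher number from compound 2 to compound 3 (0.84 log units; beyond the scatter), which leaves benzyloxy with the lowest number of the three groups at this place and the indole-bearing group with the highest, all of these steps lying beyond the scatter. Nothing available here accounts for either rise.

The three compounds cannot separate the larger ring system from the ring hydrogen that the indole brings, and a 1-methyl-1H-indol-3-yl or a naphthalen-2-yl group on the same ethenyl chain would bear directly on that question. On these data alone, it also remains open whether a carbamate cap carrying an indole, or a pyridine ring in place of the phenyl, would follow the same order in this cell read-out.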